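A few compounds are considered here, and "the series" means these few. Any claim that something is new, unique, unknown or untested is made for them only; others in the source may bear on it.

In a functional assay on BaF3 cells (Mus musculus) for antiproliferative activity (on this read-out higher numbers stand for an effect only at larger amounts of compound and lower numbers for an effect already at smaller amounts), compound 1 (`CCN1CCN(Cc2ccc(NC(=O)c3ccc(C)c(C#Cc4cccnc4)c3)cc2C(F)(F)F)CC1`) gives 1590 nM, compound 2 (`CCN1CCN(Cc2ccc(NC(=O)c3ccc(C)c(C#Cc4ccc(NC(C)=O)nc4)c3)cc2C(F)(F)F)CC1`) gives 2050 nM and compound 3 (`CCN1CCN(Cc2ccc(NC(=O)c3ccc(C)c(C#Cc4ccc(C(=O)NC)nc4)c3)cc2C(F)(F)F)CC1`) gives 3980 nM. Compound 2 therefore lies within the usual scatter of both other compounds, as a 1.9-fold higher number from compound 2 to compound 3 (0.29 log units; within the scatter) also shows.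

The unmeasured compound 4 (`CCN1CCN(Cc2ccc(NC(=O)c3ccc(C)c(C#Cc4cnccn4)c3)cc2C(F)(F)F)CC1`) differs from compound 2 by one change: pyrazin-2-yl in place of 6-acetamidopyridin-3-yl on a triple-bonded carbon. In words, this is pyrazin-2-yl in place of 6-acetamidopyridin-3-yl on a triple-bonded carbon.

Among the measured compounds shown here, no measured step makes this exact swap, and no measured compound carries pyrazin-2-yl, so that part remains untested. The closest evidence comes from two steps that add a group to the same end of the molecule. The acetamido step, a 1.3-fold higher number from compound 1 to compound 2 (0.11 log units; within the scatter), stays within the scatter, while the methylcarbamoyl step, a 2.5-fold higher number from compound 1 to compound 3 (0.40 log units; beyond the scatter), is modest. Losing the acetamido group is therefore not expected to shift this assay much.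

The expected step is a 1.2-fold lower number from compound 2 to compound 4 (0.08 log units; within the scatter), which would be no change beyond the scatter. For compound 4 the estimated value is 1700 nM, with an expected range from 600 nM to 5000 nM.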

Compound 4, half-maximal effective concentration: 2490 nM
Estimate against measurement, compound 4: 1.5-fold (0.17 log units) below; measured number inside the range.
By their numbers in this assay, from the lowest: compounds 1, 2, 4 and 3 (each within the scatter of the next, the first and the last beyond it).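

In this assay, replacing the whole ring on the triple-bonded carbon moves the number very little: pyrazin-2-yl stays within the scatter of all three earlier compounds (see a 1.2-fold higher number from compound 2 to compound 4 (0.08 log units; within the scatter); a 1.6-fold higher number from compound 1 to compound 4 (0.19 log units; within the scatter); a 1.6-fold lower number from compound 3 to compound 4 (0.20 log units; within the scatter)). The earlier steps shown here only added a group to the pyridin-3-yl ring, whereas this one shows that the ring itself can change, to one with 2 hetero atoms, and the acetamido group can go, with no step beyond the scatter. No measurement on hand offers a reason for this.

On these data alone, whether an amine or a carboxylic acid in place of the acetamido group would stay this close remains open. So does the effect of an acetamido group on the pyrazin-2-yl ring, or of a plain phenyl ring here.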